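The compounds below may be only part of what the source reports. "The series", "measured", "known", "first", "only" and "open" are said of these compounds alone.

Measured so far:
compound 1, `O=c1c2cccnc2sn1Cc1ccc(Cl)cc1`: 17500 nM
compound 2, `COc1ccc(-n2sc3ncc([N+](=O)[O-])cc3c2=O)cc1`: 3420 nM

For the measured compounds named here, in an assay for inhibition of histone acetyltransferase KAT2B (Homo sapiens), read by fluorescence (on this read-out higher numbers stand for weaker inhibition and lower numbers for stronger inhibition), compound 1 gives 17500 nM, the highest of the two numbers known so far. Compound 2 gives 3420 nM in this assay, a lower number by a margin that lies beyond the usual scatter, so compound 1 stands as the weaker of the two measured compounds. Going by the values given here, the two structures differ in more than one place, and no single step between them can be read; only the two values can be set side by side.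

Compound 3, `O=c1c2cccnc2sn1Cc1ccc(F)cc1`, is the next compound to go into this assay. It differs from compound 1 in one place: fluoro in place of chloro on an aromatic carbon. Among the compounds with values here, no measured pair shows what an exchange of one halogen for another at an aromatic carbon does here, so the size of the step rests on expectation alone. The expectation is a small step toward a slightly higher number in this assay, quite possibly within the scatter. For compound 3 the estimate is 22000 nM, with a range from 8000 nM to 60000 nM. The step this estimate implies is expected to be a 1.3-fold higher number from compound 1 to compound 3 (0.10 log units; within the scatter).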

Compound 3, half-maximal inhibitory concentration: 86300 nM
For compound 3 the middle estimate is 3.9-fold (0.59 log units) below the measured one; the measured number lies above the stated range.
By their numbers in this assay, from the lowest: compound 2; then compound 1; then compound 3.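

In this assay, for the compounds shown here, the halogen on the aromatic carbon para to a large group is not a neutral exchange: fluoro in place of chloro gives a 4.9-fold higher number from compound 1 to compound 3 (0.69 log units; beyond the scatter) and is the first step that can be read at one place. At this position, then, the assay separates the two halogens, with chloro carrying the lower number of this pair and so the stronger inhibition. Nothing available on the compounds bears on the reason for this step.

Going by these compounds alone, the single pair gives a direction between two halogens only, and with compound 1 at 17500 nM in this assay it leaves open whether bromo, methoxy or an amine on the same carbon would reach lower numbers or continue toward higher numbers. Steps linking compound 2 to compound 1 or compound 3 cannot be read, so whether the preference for chloro over fluoro holds on the core of compound 2, with its nitro group and its different aromatic substituent, also stays open.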